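Thiophen-2-yl replacing 2-fluorophenyl at the pendant aryl position

This account rests on a few compounds, and the source may have more. Where it says the series, first, only, none or still open, it means among the compounds named here.

Compound 1 `Brc1ccc(-c2cn3ccnc3c(-c3ccc4ncn(C5CCCCC5)c4c3)n2)cc1` is the reference of this pair; in a functional assay on UACC-62 cells (Homo sapiens) for inhibition, read by sulforhodamine B assay, with a stated time of 48 h, tested at 10 uM (on this read-out higher numbers stand for more inhibition at the one concentration tested (going by the name of the read-out) and lower numbers for less inhibition), compound 1 gives 46.9%. Compound 2 `Fc1ccccc1-c1cn2ccnc2c(-c2ccc3ncn(C4CCCCC4)c3c2)n1` gives 38.2% in this assay, and the step of a number 8.7 percentage points lower from compound 1 to compound 2 (within the scatter) is within the scatter. Compound 2 therefore stands as the lower of the two numbers, with compound 1 as its nearest neighbour, the gap being within the scatter of repeated measurement.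

Compound 3 `c1csc(-c2cn3ccnc3c(-c3ccc4ncn(C5CCCCC5)c4c3)n2)c1` differs from compound 2 by thiophen-2-yl in place of 2-fluorophenyl on an aromatic carbon. Among the compounds with values here, the only measured step that bears on this change is the earlier aryl swap at the same position, a number 8.7 percentage points lower from compound 1 to compound 2 (within the scatter), which was within the scatter. A second aryl swap at this position is therefore expected to give no step beyond the scatter, with the estimated step being a number 1.8 percentage points higher from compound 2 to compound 3 (within the scatter).

For compound 3 the expected value in this assay is 40%, estimated to fall between 25% and 55%.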

Compound 3, a percentage reported as inhibition, at one concentration (the size of the read-out at that concentration, not a potency): 24.8%
Beside the measured number, compound 3's estimate is 15.2 percentage points above it; the whole stated range lies above it.
By their numbers in this assay, from the lowest: compound 3; then compounds 2 and 1 (each within the scatter of the next).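

In this assay, within the data shown here, this position no longer looks indifferent to the aryl group: thiophen-2-yl in place of 2-fluorophenyl gives a number 13.4 percentage points lower from compound 2 to compound 3 (beyond the scatter) and is the first single swap here to pass the scatter. Measured against 4-bromophenyl, the same ring gives a number 22.1 percentage points lower from compound 1 to compound 3 (beyond the scatter) so the five-membered aromatic ring with a sulfur atom stands apart from both substituted phenyl groups, which remain within the scatter of each other. Nothing available explains this separation.

The compounds shown leave open whether the drop follows the five-membered ring or the sulfur atom, and a furan-2-yl group at the same carbon would bear on that. They also leave open how this position responds to a phenyl ring carrying an amine or a carboxylic acid.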